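The compounds below may be only part of what the source reports. "The series", "measured", "known", "first", "only" and "open" are said of these compounds alone.

Measured compounds so far:
compound 1, `CC(=O)OCc1ccc2oc(=O)c(C(=O)Oc3cccc(Cl)c3)cc2c1`, 49.1% in a functional assay on HT-1080 cells (Homo sapiens), read by transwell migration, with a stated time of 24 h, tested at 1 uM; on this read-out lower numbers stand for a stronger effect and higher numbers for a weaker effect at the one concentration tested
compound 2, `CC(=O)OCc1ccc2oc(=O)c(C(=O)Oc3cccc(Br)c3)cc2c1`, 21.8% in this assay
compound 3, `O=C(Oc1cccc(Cl)c1)c1cc2cc([N+](=O)[O-])ccc2oc1=O`, 65.8% in this assay

Compound 3 stands highest of the three, beyond the scatter against both others. Two single changes are covered. From compound 1 to compound 2 the change is bromo in place of chloro on an aromatic carbon and the step is a number 27.3 percentage points lower from compound 1 to compound 2 (beyond the scatter). From compound 1 to compound 3 the cores differ by nitro in place of acetoxymethyl on an aromatic carbon, and the step is a number 16.7 percentage points higher from compound 1 to compound 3 (beyond the scatter).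

Compound 4, `O=C(Oc1cccc(Br)c1)c1cc2cc([N+](=O)[O-])ccc2oc1=O`, is not yet measured. Among the compounds with values here, it differs from compound 3 by bromo in place of chloro on an aromatic carbon, the same change as the one from compound 1 to compound 2, at the same place on the same kind of ring. That change occurs twice among these four compounds, once measured. Within the data shown here, the expectation for compound 4 in this assay rests on one step only, a number 27.3 percentage points lower from compound 1 to compound 2 (beyond the scatter), with no second example to show whether the size carries over onto the core of compound 3; the step is therefore expected to be somewhat smaller, a number 22.8 percentage points lower from compound 3 to compound 4 (beyond the scatter). Compound 4 is estimated at 43%, within 26% to 60%.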

Compound 4, a percentage reported as activity, at one concentration (the size of the read-out at that concentration, not a potency): 35.2%
Compound 4: the middle estimate sits 7.8 percentage points above what was measured; low and high end bracket the measured number.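

Bromo in place of chloro carries over between the two cores in this assay with its size intact, the new step being a number 30.6 percentage points lower from compound 3 to compound 4 (beyond the scatter) and the two steps not differing: the same change on two cores in this assay, a number 27.3 percentage points lower (beyond the scatter) from compound 1 to compound 2 and a number 30.6 percentage points lower (beyond the scatter) from compound 3 to compound 4, 3.3 percentage points apart, within the scatter of two such steps. Read the other way round, nitro in place of acetoxymethyl holds its size on the bromo pair, with a number 13.4 percentage points higher from compound 2 to compound 4 (beyond the scatter) set against the step on the chloro pair: the same change on two cores in this assay, a number 16.7 percentage points higher (beyond the scatter) from compound 1 to compound 3 and a number 13.4 percentage points higher (beyond the scatter) from compound 2 to compound 4, 3.3 percentage points apart, within the scatter of two such steps. This is one closed set of four compounds with two cores and two halogens at a single concentration, so it supports additive behaviour within these four only and shows neither that the change would transfer to a third core nor why the steps agree.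

Open, as far as these compounds go, is how far the trend runs beyond bromo, for example with iodo, methyl or methoxy in its place on the phenyl ring. Also open, from the compounds shown here alone, is whether the same steps hold with an amine or a carboxylic acid in place of nitro or acetoxymethyl on the core, or with an amide in place of the ester link.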